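Three Swaps, One Level: Estimating Compound 4

The compounds below may be only part of what the source reports. "The series", "measured", "known", "first", "only" and "open" are said of these compounds alone.

Values in an ADME assay on GES1 cells (Homo sapiens) for inhibition, read by MTT assay, with a stated time of 72 h (on this read-out higher numbers stand for weaker inhibition and lower numbers for stronger inhibition), for the measured compounds:

Compound 1 `Cc1cc(Nc2ccn(Cc3cccc4ccccc34)n2)n2nc(SCc3ccc(Br)cc3)nc2n1` at 30000 nM
Compound 2 `Cc1cc(Nc2ccn(Cc3ccc(F)cc3)n2)n2nc(SCc3ccc(Br)cc3)nc2n1` at 40500 nM
Compound 3 `Cc1cc(Nc2ccn(Cc3nc(C)c4ccccc4n3)n2)n2nc(SCc3ccc(Br)cc3)nc2n1` at 36800 nM

Compound 3 stands level with the other two, its value of 36800 nM lying within the scatter of both, as a 1.2-fold higher number from compound 1 to compound 3 (0.09 log units; within the scatter) and a 1.1-fold lower number from compound 2 to compound 3 (0.04 log units; within the scatter) show. Compound 4 `Cc1ccc(Cn2ccc(Nc3cc(C)nc4nc(SCc5ccc(Br)cc5)nn34)n2)cc1` carries 4-methylphenyl in place of 4-methylquinazolin-2-yl on a saturated chain carbon bound to an aromatic nitrogen and is otherwise the same. The same place changes in a 1.4-fold higher number from compound 1 to compound 2 (0.13 log units; within the scatter) and in the two steps to compound 3, and none of the three passes the scatter, so no step beyond it is expected in this assay in either direction. The expected step is a 1.0-fold higher number from compound 3 to compound 4 (0.00 log units; within the scatter) as an estimate only. Compound 4 is estimated at 37000 nM with an expected range from 24000 nM to 58000 nM in repeated measurements.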

Compound 4, half-maximal inhibitory concentration: > 50000 nM
Compound 4 was reported as a limit (the forecaster's own chance of this, stated with the estimate: 10%); middle value at least 1.3-fold (0.13 log units) away from the limit.
By their numbers in this assay, from the lowest: compounds 1, 3 and 2 (each within the scatter of the next). At a limit, above all of these: compound 4.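

In this assay, among the compounds shown here, compound 4 is the first compound with this position changed that gives a limit rather than a number: the limit of > 50000 nM in this assay, at which 1 of the 4 values shown sits. The floors of its steps, an at least 1.3-fold higher number from compound 3 to compound 4 (0.13 log units; that floor lies within the scatter), an at least 1.2-fold higher number from compound 2 to compound 4 (0.09 log units; that floor lies within the scatter) and an at least 1.6-fold higher number from compound 1 to compound 4 (0.22 log units; that floor lies within the scatter), all lie within the scatter, so the limit does not separate compound 4 from the other three. The position on a saturated chain carbon bound to an aromatic nitrogen thus gains a fourth group, 4-methylphenyl, and the swap of methyl for fluoro on an aromatic carbon adds a comparison that has only a floor and no upper bound.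

From the compounds shown here alone, how far compound 4 really lies from the other three remains open. So does what an amine or a carboxylic acid at this place would give in this assay.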